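A few compounds are considered here, and "the series" means these few. Any claim that something is new, unique, unknown or untested is made for them only; others in the source may bear on it.

Measured compounds:
Compound 1 `COc1ccc(-c2cc(/C=C/C(=O)c3ccc(OC)c(OC)c3)[nH]n2)cc1` — 89%
Compound 2 `COc1cc(-c2cc(/C=C/C(=O)c3ccc(Cl)c(Cl)c3)[nH]n2)cc(OC)c1OC` — 99%
Compound 3 `COc1ccc(-c2cc(/C=C/C(=O)c3ccc(N)cc3)[nH]n2)cc1` — 95%

Of the compounds shown here, three sharing one core have been tested in a functional assay on OVCAR-5 cells (Homo sapiens) for cytotoxicity, read by sulforhodamine B assay, with a stated time of 48 h, tested at 0.1 uM; on this read-out lower numbers stand for a stronger effect and higher numbers for a weaker effect at the one concentration tested. In this assay compound 2 gives 99%, the highest of the three numbers, yet compound 3 with 95% and compound 1 with 89% both fall within the scatter of it, so the three values show no order among themselves; all three sit close to the weak end of the read-out.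

Compound 4 `COc1ccc(C(=O)/C=C/c2cc(-c3cc(OC)c(OC)c(OC)c3)n[nH]2)cc1OC` has not yet been measured in this assay. Compared with compound 2 it carries 3,4-dimethoxyphenyl in place of 3,4-dichlorophenyl on a carbonyl carbon. Among the measured compounds shown here, no step between two measured compounds isolates this change. Compound 1 also carries the 3,4-dimethoxyphenyl group on a carbonyl carbon and gives 89%, though it differs from compound 4 elsewhere as well.

Given that, compound 4 is expected to give 92% in this assay, in the range 78% to 104%. The expected step from compound 2 to compound 4 is a number 7 percentage points lower from compound 2 to compound 4 (within the scatter), a change that is estimated to stay within the usual scatter, with no clear gain in effect.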

Compound 4, a percentage reported as activity, at one concentration (the size of the read-out at that concentration, not a potency): 88%
Compound 4: the middle estimate sits 4 percentage points above what was measured, within the range that was stated.
By their numbers in this assay, from the lowest: compounds 4, 1, 3 and 2 (each within the scatter of the next, the first and the last beyond it).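

In this assay, among the compounds shown here, the exchange of 3,4-dichlorophenyl for 3,4-dimethoxyphenyl on a carbonyl carbon gives a number 11 percentage points lower from compound 2 to compound 4 (beyond the scatter) and so provides the first reading that isolates one place, a modest step that the earlier compounds, which differ from each other in more than one place, could not offer. It shows that the number responds to the group on this carbonyl carbon, although compound 4 at 88% still lies near the weak end of the read-out. Nothing available explains this step.

As far as these compounds go, whether a carboxylic acid or a longer alkoxy chain on that carbonyl carbon would move the number further remains open. Also open, from the compounds shown here alone, is whether the same exchange would give a similar step on the core of compound 1 or at other concentrations.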